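The source may hold more compounds than are shown below. What is called first, only, known or untested is meant among the compounds shown, and "the series" means these compounds.

Among the compounds with values here, compound 2 `O=C(O)CCc1ccc(C#Cc2ccnc(Cl)n2)cc1` gives 131% in an in vitro functional assay on 1321-N1 cells for agonist activity at Free fatty acid receptor 1 (Homo sapiens), read by fluorescence, spectrophotometry and calcium flux (on this read-out lower numbers stand for smaller maximal responses and higher numbers for larger maximal responses), the higher of the two measured numbers; compound 1 `Cc1cc(C#Cc2ccc(CCC(=O)O)cc2)nc(Cl)n1` gives 110%, and the step of a number 21 percentage points higher from compound 1 to compound 2 (beyond the scatter) is the only step measured so far. Compound 3 `COc1nccc(C#Cc2ccc(CCC(=O)O)cc2)n1` differs from compound 2 by methoxy in place of chloro on an aromatic carbon. Within the data shown here, the one measured step concerns a methyl-for-hydrogen change on a different carbon, so it does not bear on this swap, and no measured pair covers methoxy in place of chloro. The step of a number 11 percentage points lower from compound 2 to compound 3 (beyond the scatter) is therefore expected to be small, most likely within the scatter. Compound 3 is estimated at 120%, between 90% and 150%.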

Compound 3, largest response reached (reported as efficacy), in percent of the reference or control that the assay uses: 109%
Compound 3: middle estimate off by 11 percentage points, on the high side; the measured number falls inside the stated range.
By their numbers in this assay, from the lowest: compounds 3 and 1 (each within the scatter of the next); then compound 2.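

Methoxy in place of chloro, on the carbon between two ring nitrogen atoms, gives a number 22 percentage points lower from compound 2 to compound 3 (beyond the scatter). Within the data shown here, the earlier pair kept chloro at this carbon, so this is the first sign that the group here changes the maximal response, although compound 3 still reaches 109%. Nothing measured here explains the drop.

From the compounds shown here alone, whether an amine or a fluoro group on this carbon would keep the response of compound 2 stays open. So does whether the same swap would give a similar step on the core of compound 1, which carries the methyl group.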